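A few compounds are considered here, and "the series" means these few. Any claim that something is new, unique, unknown or untested is made for them only; others in the source may bear on it.

Measured so far in a functional assay on Gurav cells (Homo sapiens) for inhibition, read by sulforhodamine B assay; a lower number here means a stronger inhibitor of growth, a higher number a weaker inhibitor of growth:
- compound 1 `c1ccc(-c2ccc(-c3ccc(-c4nc5ccccc5[nH]4)cc3)cc2)cc1`: 100000 nM
- compound 2 `FC(F)(F)c1ccc(-c2ccc(-c3ccc(-c4nc5ccccc5[nH]4)cc3)cc2)cc1`: 39100 nM

Compound 2 has the lower of these two numbers, so it is the stronger inhibitor of growth so far, though still a weak one on the numbers alone. Compound 3 `Oc1ccc(-c2ccc(-c3ccc(-c4nc5ccccc5[nH]4)cc3)cc2)cc1` keeps the shared core but has hydroxy in place of trifluoromethyl on an aromatic carbon, para to a large group: hydroxy in place of trifluoromethyl on an aromatic carbon. Among the measured compounds shown here, only one measured step bears on this change, and it concerns the same aromatic carbon: a 2.6-fold lower number from compound 1 to compound 2 (0.41 log units; beyond the scatter). That step was modest. For the measured compounds named here, no measured compound carries hydroxy, so the data give no direction for this swap. A step of similar modest size could go either way, so no step beyond the scatter is expected in this assay. The estimated value for compound 3 is 40000 nM, with an expected range of 10000 nM to 100000 nM. The expected step is a 1.0-fold higher number from compound 2 to compound 3 (0.01 log units; within the scatter).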

Compound 3, concentration for 50% growth inhibition: 100000 nM
Estimate against measurement, compound 3: 2.5-fold (0.40 log units) below; the measured number falls inside the stated range.
By their numbers in this assay, from the lowest: compound 2; then compounds 1 and 3 (each within the scatter of the next).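

In this assay, putting hydroxy in place of trifluoromethyl on this aromatic carbon gives a 2.6-fold higher number from compound 2 to compound 3 (0.41 log units; beyond the scatter) and so loses the gain that trifluoromethyl brought. Hydroxy in place of hydrogen at the same carbon gives no change at the digits printed from compound 1 to compound 3 (within the scatter) and so shows that adding just any group here does not lower the number: of the two groups shown at this carbon, only trifluoromethyl does. Nothing available explains why these two groups behave differently.

The compounds shown leave open whether other groups on this carbon, such as an amine, a carboxylic acid or a longer chain, would match trifluoromethyl or lower the number further. They also leave open whether the gain from trifluoromethyl would hold if the group sat anywhere else on the shared core.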